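The source may hold more compounds than are shown below. What is called first, only, known or untested is meant among the compounds shown, and "the series" means these compounds.

Compound 3 `COc1cc(N)c(Cl)cc1C(=O)NC1CCN(CCCCCCCCN2CCCCC2)CC1` gives the lowest number of the three compounds measured in an assay on HEK293 cells for displacement of a labelled ligand from 5-hydroxytryptamine receptor 4 (Homo sapiens), read by scintillation counting (on this read-out lower numbers stand for stronger inhibition and higher numbers for weaker inhibition), at 3.16 nM. Compound 1 `COc1cc(N)c(Cl)cc1C(=O)NC1CCN(CCCCCCCCO)CC1` gives 79.4 nM in this assay, and compound 2 `COc1cc(N)c(Cl)cc1C(=O)NC1CCN(CCCCCCCCN2C(=O)c3ccccc3C2=O)CC1` gives 39.8 nM. Compound 4 `COc1cc(N)c(Cl)cc1C(=O)NC1CCN(CCCCCCCCN2CCN(S(C)(=O)=O)CC2)CC1` has not yet been measured; it differs from compound 3 by 4-(methylsulfonyl)piperazin-1-yl in place of piperidin-1-yl on a saturated chain carbon, eight bonds along the chain from an amine nitrogen in a ring. For the measured compounds named here, two measured steps bear on this change, since each alters the same group at the end of the chain: a 25-fold lower number from compound 1 to compound 3 (1.40 log units; beyond the scatter) and a 13-fold lower number from compound 2 to compound 3 (1.10 log units; beyond the scatter). Both steps were large, and both ended at the piperidin-1-yl group of compound 3, which gave the lowest number. Compound 4 keeps a six-membered ring with a nitrogen at this place, so a step as large as those from compound 1 or compound 2 is not expected, but the added ring nitrogen and methylsulfonyl group leave room for some rise. For compound 4 the expected step in this assay is a 4.7-fold higher number from compound 3 to compound 4 (0.68 log units; beyond the scatter), a moderate rise. Compound 4 is therefore estimated at 15 nM, within a range of 4 nM to 60 nM.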

Compound 4, inhibition constant: 15.9 nM
Beside the measured number, compound 4's estimate is 1.1-fold (0.03 log units) below it; the measured number falls inside the stated range.
By their numbers in this assay, from the lowest: compound 3; then compound 4; then compounds 2 and 1 (each within the scatter of the next).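

In this assay, replacing piperidin-1-yl with 4-(methylsulfonyl)piperazin-1-yl at the end of the chain gives a 5.0-fold higher number from compound 3 to compound 4 (0.70 log units; beyond the scatter), the first step measured away from compound 3 to a group that also keeps a six-membered ring with nitrogen at this place. The same group still improves on the two other end groups, with a 2.5-fold lower number from compound 2 to compound 4 (0.40 log units; beyond the scatter) and a 5.0-fold lower number from compound 1 to compound 4 (0.70 log units; beyond the scatter), so compound 4 falls in the gap that had separated compound 3 from compounds 1 and 2. Nothing available accounts for these differences.

The compounds shown do not separate the effect of the second ring nitrogen from that of the methylsulfonyl group, a question on which an unsubstituted piperazin-1-yl or a morpholin-4-yl group would bear. They also leave open whether this order of end groups holds on a shorter chain.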